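The source may hold more compounds than are shown below. What is called first, only, known or untested is meant among the compounds shown, and "the series" means these compounds.

In a physicochemical assay for solubility, at pH 7.4 (a higher number here means a more soluble compound, a lower number a less soluble compound), compound 2 `CC(=O)OCCCS(=O)(=O)c1ccc(S(N)(=O)=O)s1` gives 920 ug/mL, second highest of the three numbers. Compound 1 `NS(=O)(=O)c1ccc(S(=O)(=O)CCCO)s1` gives 14600 ug/mL and compound 3 `CC(C)COC(=O)OCCCS(=O)(=O)c1ccc(S(N)(=O)=O)s1` gives 80 ug/mL. Compound 4 `NS(=O)(=O)c1ccc(S(=O)(=O)CCCCO)s1` is unmeasured. Its change from compound 2 is hydroxymethyl in place of acetoxy on a saturated chain carbon, three bonds along the chain from a sulfonyl sulfur. The closest measured precedent is the large 16-fold lower number from compound 1 to compound 2 (1.20 log units; beyond the scatter), which adds an acetyl to a free hydroxyl and is read here in reverse, although the chains differ. The large 12-fold lower number from compound 2 to compound 3 (1.06 log units; beyond the scatter) concerns only the capping group and bears less. The expected step is a 6.5-fold higher number from compound 2 to compound 4 (0.81 log units; beyond the scatter), towards a higher number and beyond the scatter. For compound 4 the estimate is 6000 ug/mL, with an expected range of 2500 ug/mL to 14000 ug/mL.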

Compound 4, solubility: 9900 ug/mL
Estimate against measurement, compound 4: 1.7-fold (0.22 log units) below; the range from low to high includes it.
By their numbers in this assay, from the lowest: compound 3; then compound 2; then compounds 4 and 1 (each within the scatter of the next).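

In this assay, within the data shown here, the swap of acetoxy for hydroxymethyl on this saturated chain carbon gives a large step (an 11-fold higher number from compound 2 to compound 4 (1.03 log units; beyond the scatter)), comparable in size to the earlier steps on the capping group. Hydroxymethyl in place of hydroxy at the same place gives no step beyond the scatter (a 1.5-fold lower number from compound 1 to compound 4 (0.17 log units; within the scatter)), so this change to the free-hydroxyl chain leaves the number unresolved from compound 1. No measured evidence accounts for either step. The compounds shown leave open how an amine, a carboxylic acid or a longer chain ending in hydroxyl would read at this position.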